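This account rests on a few compounds, and the source may have more. Where it says the series, first, only, none or still open, it means among the compounds named here.

In a functional assay on HOP-62 cells (Homo sapiens) for inhibition, read by sulforhodamine B assay (a higher number here means a weaker inhibitor of growth, a lower number a stronger inhibitor of growth), compound 1 `Fc1ccc(-c2ccc(-c3ccc(-c4nc5ccccc5[nH]4)cc3)cc2)cc1` gives 39300 nM and compound 2 `Oc1ccc(-c2ccc(-c3ccc(-c4nc5ccccc5[nH]4)cc3)cc2)cc1` gives 47200 nM. Among the measured compounds shown here, compound 2 therefore stands level with its only measured neighbour, and the measured step between them, a 1.2-fold higher number from compound 1 to compound 2 (0.08 log units; within the scatter), lies within the scatter. Compound 3 `Clc1cccc(-c2ccc(-c3ccc(-c4nc5ccccc5[nH]4)cc3)cc2)c1` keeps the shared core but carries 3-chlorophenyl in place of 4-hydroxyphenyl on an aromatic carbon. For the measured compounds named here, only that one measured step bears on this change, and it is a loose guide, since no compound measured so far contains chlorine. Even so, replacing fluoro with hydroxy left this assay without a shift beyond the scatter, so no clear step in either direction is expected here. The estimate is a 1.2-fold lower number from compound 2 to compound 3 (0.07 log units; within the scatter), which is expected to stay within the scatter. Compound 3 is expected at 40000 nM, with an estimated range from 15000 nM to 90000 nM.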

Compound 3, concentration for 50% growth inhibition: 100000 nM
Beside the measured number, compound 3's estimate is 2.5-fold (0.40 log units) below it; measured number above the stated range.
By their numbers in this assay, from the lowest: compounds 1 and 2 (each within the scatter of the next); then compound 3.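

In this assay, this position proves more sensitive than the fluoro-to-hydroxy swap suggested, with a 2.1-fold higher number from compound 2 to compound 3 (0.33 log units; beyond the scatter) and a 2.5-fold higher number from compound 1 to compound 3 (0.41 log units; beyond the scatter), both pointing to weaker growth inhibition. So 3-chlorophenyl does worse here than either 4-hydroxyphenyl or 4-fluorophenyl, even though those two groups stand level with each other. Nothing available explains this shift.

This change alters both the atom on the outer ring and where that atom sits, and the compounds shown do not separate those two changes; a 4-chlorophenyl group would help to tell them apart. Also open, as far as these compounds go, is whether any group at this position, such as an amine or a carboxylic acid on the outer ring, would give a markedly lower number than these three compounds.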